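A few compounds are considered here, and "the series" means these few. Any claim that something is new, unique, unknown or untested is made for them only; others in the source may bear on it.

Compound 1 `CC(CCCC(=O)O)c1cccc(OCc2ccc3ccccc3n2)c1` gives 90 nM in an assay on membranes from lung (Cavia porcellus) for binding affinity to cysteinyl leukotriene receptor (Homo sapiens); on this read-out lower numbers stand for stronger inhibition and higher numbers for weaker inhibition. Among the three measured compounds it has the second highest number: compound 2 `O=C(O)CCCCc1cccc(OCc2ccc3ccccc3n2)c1` gives 100 nM, a change of a 1.1-fold higher number from compound 1 to compound 2 (0.05 log units; within the scatter), while compound 3 `CC(Cc1cccc(OCc2ccc3ccccc3n2)c1)CC(C)C(=O)O` gives 24 nM, a change of a 3.8-fold lower number from compound 1 to compound 3 (0.57 log units; beyond the scatter). Compound 4 `CC(CCCc1nnn[nH]1)c1cccc(OCc2ccc3ccccc3n2)c1` differs from compound 1 in one place: 1H-tetrazol-5-yl in place of carboxy on a saturated chain carbon, four bonds along the chain from an aromatic carbon. For the measured compounds named here, none of the measured steps touches the acid end of the chain; each of them alters only the carbon chain between the shared core and that acid. With nothing measured on the acid group itself, the expectation is a step of no change at the digits printed from compound 1 to compound 4 (within the scatter), none beyond the scatter. Compound 4 is therefore estimated at 90 nM, with a range from 30 nM to 270 nM.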

Compound 4, inhibition constant: 31 nM
Compound 4: the middle estimate sits 2.9-fold (0.46 log units) above what was measured, within the range that was stated.
By their numbers in this assay, from the lowest: compounds 3 and 4 (each within the scatter of the next); then compounds 1 and 2 (each within the scatter of the next).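

Replacing carboxy with 1H-tetrazol-5-yl, on a saturated chain carbon, four bonds along the chain from an aromatic carbon, gives a 2.9-fold lower number from compound 1 to compound 4 (0.46 log units; beyond the scatter), a step beyond the scatter. For the compounds shown here, the group at this place can therefore be exchanged for a five-membered aromatic ring with 4 hetero atoms without losing binding, and the earlier compounds, which altered only the carbon chain, could not show this. No measurement at hand explains the change.

Still open, on these data alone, is whether the same exchange lowers the number on the chain of compound 3. An amide or a sulfonic acid at this place also remains untested in the compounds shown.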